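The source may hold more compounds than are shown below. What is called first, only, known or untested is meant among the compounds shown, and "the series" means these compounds.

Compound 1 `COc1ccc(C(=O)c2ccc(OC)c3c2OC(C)(C)C=C3)c(NC(=O)CBr)c1` gives 2360 nM
Compound 2 `C=C(c1ccc(OC)cc1NC(=O)CO)c1ccc(OC)c2c1OC(C)(C)C=C2` gives 100 nM
Compound 3 `C=C(c1ccc(OC)cc1NC(=O)CO)c1ccc(OC)c2c1C=CC(C)(C)O2` gives 590 nM

These numbers come from a functional assay on MCF7 cells (Homo sapiens) for antiproliferative activity, read by MTT assay, with a stated time of 48 h (on this read-out higher numbers stand for weaker inhibition and lower numbers for stronger inhibition), and compound 2 stands lowest of the three (100 nM). Compound 3 and compound 1 both lie higher, and both gaps to compound 2 go beyond the usual scatter of repeated measurements.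

Compound 4 `C=C(c1ccc(OC)cc1NC(=O)CNCC)c1ccc(OC)c2c1OC(C)(C)C=C2` still awaits a number in this assay and differs from compound 2 in one place: ethylamino in place of hydroxy on a saturated chain carbon bound to a carbonyl carbon. Going by the values given here, no two measured compounds differ in just one place, so the data say nothing direct about this swap. Among the compounds with values here, compound 2 already holds the lowest number so far (100 nM), so a rise looks likelier than a further fall. A moderate weakening is expected, estimated as a 2.5-fold higher number from compound 2 to compound 4 (0.40 log units; beyond the scatter) and not certain to clear the scatter. The expected value for compound 4 is 250 nM with an estimated range from 60 nM to 1000 nM.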

Compound 4, half-maximal inhibitory concentration: 2100 nM
Compound 4: middle estimate off by 8.4-fold (0.92 log units), on the low side, and the stated range ends below it.
By their numbers in this assay, from the lowest: compound 2; then compound 3; then compounds 4 and 1 (each within the scatter of the next).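

In this assay the step from hydroxy to ethylamino on a saturated chain carbon bound to a carbonyl carbon is large, with a 21-fold higher number from compound 2 to compound 4 (1.32 log units; beyond the scatter) showing that this end of the side chain strongly affects the result. The entering group has more heavy atoms than the one it replaces, yet both carry the same counted hydrogen-bond donors and acceptors and no net charge, so those counts alone do not separate compound 2 from compound 4. No supporting measurement bears on why the number rises.

The two compounds leave open whether the rise goes with the nitrogen or with the added ethyl carbons. A plain amino group, a methylamino group or an ethoxy group at the same place would help separate these two possibilities.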